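Methoxy to Hydroxy in Two Matched Pairs

The compounds below may be only part of what the source reports. "The series", "measured", "known", "first", "only" and "open" are said of these compounds alone.

Measured in a functional assay on UACC-257 cells (Homo sapiens) for inhibition, read by sulforhodamine B assay, with a stated time of 48 h; on this read-out lower numbers stand for higher toxicity in this test and higher numbers for lower toxicity in this test:
compound 1 `COc1cc(-c2nn(-c3cccc(NC(=O)Nc4cc(C(F)(F)F)cc(C(F)(F)F)c4)c3)cc2-c2ccncc2)ccc1Cl` gives 26200 nM
compound 2 `O=C(Nc1cccc(-n2cc(-c3ccncc3)c(-c3ccc(Cl)c(O)c3)n2)c1)Nc1cc(C(F)(F)F)cc(C(F)(F)F)c1` gives 10600 nM
compound 3 `COc1cc(-c2nn(-c3cccc(NC(=O)Nc4ccc(Cl)c(C(F)(F)F)c4)c3)cc2-c2ccncc2)ccc1Cl` gives 29200 nM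

Compound 3 carries the highest number of the three, but its distance from compound 1 lies within the scatter, so the two cannot be told apart. Compound 2 alone stands clearly apart with its lower number. The difference between the core of compound 1 and the core of compound 3 is not broken down here.

Compound 1 and compound 2 differ only by hydrogen in place of methyl on an oxygen on an aromatic ring, and this change produced a 2.5-fold lower number from compound 1 to compound 2 (0.39 log units; beyond the scatter).

Compound 4 `O=C(Nc1cccc(-n2cc(-c3ccncc3)c(-c3ccc(Cl)c(O)c3)n2)c1)Nc1ccc(Cl)c(C(F)(F)F)c1` is not yet measured. It differs from compound 3 by hydrogen in place of methyl on an oxygen on an aromatic ring, the same change at the same place, now on the core of compound 3 instead of the core of compound 1. Since the change has only been seen once, the expectation leans on that single step. The step from compound 3 to compound 4 is expected to be a 2.4-fold lower number from compound 3 to compound 4 (0.39 log units; beyond the scatter), roughly matching the step from compound 1 to compound 2 in this assay. Compound 4 is therefore estimated at 12000 nM, with a likely range from 5500 nM to 26000 nM.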

Compound 4, concentration lethal to 50% of the cells: 8390 nM
The estimate for compound 4 lay 1.4-fold (0.16 log units) above the measured number; low and high end bracket the measured number.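

On the second core, the change from methoxy to hydroxy gave a 3.5-fold lower number from compound 3 to compound 4 (0.54 log units; beyond the scatter) in this assay. The change moved the number the same way on both cores, and the two steps cannot be told apart: the same change on two cores in this assay, a 2.5-fold lower number (0.39 log units; beyond the scatter) from compound 1 to compound 2 and a 3.5-fold lower number (0.54 log units; beyond the scatter) from compound 3 to compound 4, 1.4-fold (0.15 log units) apart, within the scatter of two such steps. Among the compounds shown here, this shows that the step carried over from one core to the other in direction and roughly in size, but with only two pairs it does not show that the same would hold on any further core, nor does it explain why the number falls.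

The compounds shown leave open whether hydroxy is the only replacement for methoxy that lowers the number, since an amine, a carboxylic acid or a longer chain such as ethoxy at the same place would test this. They also leave open whether the step depends on the chlorine of the 4-chloro-3-hydroxyphenyl group, which stays the same in all four compounds.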